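This account rests on a few compounds, and the source may have more. Where it says the series, first, only, none or still open, it means among the compounds named here.

Of the compounds shown here, two have been measured in a functional assay for inhibition of sodium/hydrogen exchanger (Oryctolagus cuniculus); a lower number here means a stronger inhibitor, a higher number a weaker inhibitor. Compound 1 `Cc1c(C(=O)N=C(N)N)cc(S(C)(=O)=O)c(Cl)c1Cl` gives 29 nM. For the measured compounds named here, compound 2 `Cc1cc(-c2ccc(Cl)cc2Cl)c(S(C)(=O)=O)cc1C(=O)N=C(N)N` gives 42 nM; compound 1 is its only neighbour, and the gap between the two values is within the usual scatter. Compound 3 `Cc1cc(OCc2ccccc2)c(S(C)(=O)=O)cc1C(=O)N=C(N)N` has not yet been measured. It differs from compound 2 in one place: benzyloxy in place of 2,4-dichlorophenyl on an aromatic carbon. Going by the values given here, no measured pair shows this change, so its effect is unknown. A modest rise in the number, somewhat beyond the scatter, is expected for the step of a 2.1-fold higher number from compound 2 to compound 3 (0.33 log units; beyond the scatter). For compound 3 the estimate is 90 nM, with a range from 25 nM to 350 nM.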

Compound 3, half-maximal inhibitory concentration: 28 nM
The estimate for compound 3 lay 3.2-fold (0.51 log units) above the measured number; the measured number falls inside the stated range.
By their numbers in this assay, from the lowest: compounds 3, 1 and 2 (each within the scatter of the next).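

In this assay, placing benzyloxy instead of 2,4-dichlorophenyl on this aromatic carbon, ortho to the methylsulfonyl group, gives a 1.5-fold lower number from compound 2 to compound 3 (0.18 log units; within the scatter) and so makes no readable difference. Two different groups, one of them carrying an oxygen, can therefore stand at this position with no change beyond the scatter. No other measurement bears on this result. From the compounds shown here alone, whether an amine, a carboxylic acid or a longer alkyl chain at this position would keep the number in the same range remains open.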